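Trimming the Trimethoxyphenyl: Expecting Compound 4

The compounds below may be only part of what the source reports. "The series", "measured", "known", "first", "only" and "open" are said of these compounds alone.

Measured so far in an ADME assay on Vero cells (Chlorocebus sabaeus) for cytotoxicity, read by MTT assay, with a stated time of 72 h; on this read-out higher numbers stand for lower toxicity in this test and lower numbers for higher toxicity in this test:
Compound 1 `COC(=O)c1cc(-c2cccc(NC(=O)c3ccc(/C=C/C(=O)c4cc(OC)c(OC)c(OC)c4)cc3)c2)on1` gives > 50 ug/mL; this value is a limit of the assay, not a number.
Compound 2 `COC(=O)c1cc(-c2cccc(NC(=O)c3ccc(/C=C/C(=O)c4cccc(Cl)c4)cc3)c2)on1` gives > 2.5 ug/mL; this value is also a limit.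
Compound 3 `COC(=O)c1cc(-c2cccc(NC(=O)c3ccc(/C=C/C(=O)c4ccc(F)cc4F)cc3)c2)on1` gives > 40 ug/mL; this value is also a limit.

For the measured compounds named here, compound 1 stands only at a limit in this assay, and the two other values are limits as well, so no compound can be placed relative to another. The steps a step that the two limits leave unreadable from compound 1 to compound 2, a step that the two limits leave unreadable from compound 1 to compound 3 and a step that the two limits leave unreadable from compound 2 to compound 3 are all unreadable. Compound 4 `COC(=O)c1cc(-c2cccc(NC(=O)c3ccc(/C=C/C(=O)c4cccc(OC)c4)cc3)c2)on1` differs from compound 1 by 3-methoxyphenyl in place of 3,4,5-trimethoxyphenyl on a carbonyl carbon. The measured steps that bear on this change replace the same group on the carbonyl carbon, yet none has a readable size, so no direction or size beyond the scatter can be foreseen in this assay. The expected step is a number no higher from compound 1 to compound 4 (the limit leaves the size open). Compound 4 is estimated at 50 ug/mL, with a range from 20 ug/mL to 100 ug/mL.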

Compound 4, half-maximal cytotoxic concentration: > 100 ug/mL
Compound 4 gave a limit, no number (the forecaster's own chance of this, stated with the estimate: 70%); middle value at least 2.0-fold (0.30 log units) from the limit.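

For the compounds shown here, compound 4 gives only a limit in this assay, as do compound 1, compound 2 and compound 3, so no step to compound 4 can be read. The compounds shown leave open whether changing the group on the carbonyl carbon alters toxicity in this test at all.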